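Urea to benzamide: expectation for compound 3

The source may hold more compounds than are shown below. What is called first, only, known or untested is meant among the compounds shown, and "the series" means these compounds.

Measured so far:
Compound 1 `COc1cc(-c2nn(-c3cccc(NC(=O)Nc4ccc(Cl)c(Cl)c4)c3)cc2-c2ccncc2)ccc1Cl` — in a functional assay on HCT-116 cells (Homo sapiens) for inhibition, read by sulforhodamine B assay, with a stated time of 48 h (on this read-out lower numbers stand for stronger inhibition of growth and higher numbers for weaker inhibition of growth), compound 1 gives only a limit, > 50000 nM.
Compound 2 `COc1cc(-c2nn(-c3cccc(NC(=O)Nc4ccc(Cl)c(C(F)(F)F)c4)c3)cc2-c2ccncc2)ccc1Cl` — in this assay compound 2 gives 4560 nM.

Going by the values given here, compound 2 holds the only actual number in this assay; the other value is a limit (the limit of > 50000 nM in this assay, at which 1 of the 2 values shown sits). Among the compounds with values here, the single measured step, an at least 10-fold lower number from compound 1 to compound 2 (1.04 log units; beyond the scatter), is large, so the substituent pattern of the aryl on the urea clearly matters to this read-out.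

Compound 3 `COc1cc(-c2nn(-c3cccc(NC(=O)c4ccccc4)c3)cc2-c2ccncc2)ccc1Cl` is not yet measured. Relative to compound 2 it carries phenyl in place of (4-chloro-3-(trifluoromethyl)phenyl)amino on a carbonyl carbon. Within the data shown here, no measured step covers a change of this kind: the whole (4-chloro-3-(trifluoromethyl)phenyl)amino group goes and a plain phenyl remains on the carbonyl carbon. Because an at least 10-fold lower number from compound 1 to compound 2 (1.04 log units; beyond the scatter) showed the read-out reacting strongly even to a change within that aryl group, its complete removal is expected to weaken growth inhibition. The expected step is a 4.4-fold higher number from compound 2 to compound 3 (0.64 log units; beyond the scatter). Compound 3 is estimated at 20000 nM, with a range from 5000 nM to 60000 nM, and a limit-only result is a real possibility.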

Compound 3, concentration for total growth inhibition: > 100000 nM
Compound 3 ended at the assay's limit; the forecaster's own chance of this, stated with the estimate: 35%; at least 5.0-fold (0.69 log units) between middle value and limit.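

In this assay, compound 3 gives only a limit, not a number: the limit of > 100000 nM in this assay, at which 1 of the 3 values shown sits. Phenyl in place of (4-chloro-3-(trifluoromethyl)phenyl)amino on the carbonyl carbon gives an at least 21-fold higher number from compound 2 to compound 3 (1.34 log units; beyond the scatter), so this position responds strongly not only to a substituent change within the aryl group but also to replacement of the whole group. The step between compound 1 and compound 3 cannot be read, as both values are limits.

This change removes the amino nitrogen and the chloro and trifluoromethyl substituents together, and the compounds shown do not separate these parts. Also open, as far as these compounds go, is whether a benzamide phenyl carrying trifluoromethyl or a morpholine would give a number rather than a limit.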